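The compounds below may be only part of what the source reports. "The series", "measured", "known", "first", "only" and "open" are said of these compounds alone.

Compound 1 `c1ccc2c(c1)CC2CCCCN1CCN(c2cccc3c2OCCO3)CC1` and compound 2 `c1ccc2c(c1)CCC2CCN1CCN(c2cccc3c2OCCO3)CC1` share the same core and differ only in the saturated part that carries the second ring system. In an assay on isolated protein for binding affinity to 5-hydroxytryptamine receptor 1B (Rattus norvegicus) (on this read-out lower numbers stand for stronger inhibition and higher numbers for weaker inhibition), compound 1 gives 631 nM, and in this assay compound 2 gives 417 nM; these two numbers lie within the usual scatter of each other, so neither compound stands apart. Compound 3 `c1ccc2c(c1)CC(CCCN1CCN(c3cccc4c3OCCO4)CC1)C2` has the same atoms as compound 1, joined differently: a group of 9 heavy atoms (9 carbon; one five-membered non-aromatic ring of carbon only, one six-membered aromatic ring of carbon only) in place of a group of 9 heavy atoms (9 carbon; one four-membered non-aromatic ring of carbon only, one six-membered aromatic ring of carbon only), on a saturated chain carbon, three bonds along the chain from an amine nitrogen in a ring. Among the compounds with values here, no measured pair shows a change of this kind, so no step beyond the scatter is expected in either direction. Compound 3 is therefore estimated at 450 nM, between 150 nM and 1400 nM, which means an expected step of a 1.4-fold lower number from compound 1 to compound 3 (0.15 log units; within the scatter).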

Compound 3, inhibition constant: 1860 nM
For compound 3 the middle estimate is 4.1-fold (0.62 log units) below the measured one, outside the stated range (above it).
By their numbers in this assay, from the lowest: compounds 2 and 1 (each within the scatter of the next); then compound 3.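

In this assay there is a 2.9-fold higher number from compound 1 to compound 3 (0.47 log units; beyond the scatter) when 2,3-dihydro-1H-inden-2-yl enters on a saturated chain carbon, in place of the group with the four-membered ring. The atoms stay the same, so this position responds to how the carbons are joined, not only to which atoms are present. Nothing measured here explains this step. Still open, from the compounds shown here alone, is whether a longer chain would carry this difference over, and whether a hydroxyl group on the five-membered ring would move the number in either direction.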